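Shortening the amide chain from sec-butyl to propyl

The compounds below may be only part of what the source reports. "The series", "measured", "known", "first", "only" and "open" are said of these compounds alone.

Three compounds sharing one core were measured in a functional assay on the whole organism for inhibition, with Brassica rapa subsp. chinensis as the target, with a stated time of 3 days, tested at 100 ppm; a higher number here means more inhibition of growth at the concentration tested, a lower number less inhibition of growth. Compound 1 `CC(C)NC(=O)/C=C/c1ccccc1` gives 76%. Compound 2 `CCCCCCCCNC(=O)/C=C/c1ccccc1` gives 42%. Compound 3 `CCC(C)NC(=O)/C=C/c1ccccc1` gives 77%, a number that sits within the scatter of that of compound 1 and well beyond the scatter from that of compound 2. Within the data shown here, the one measured step between compounds differing in a single place, a number 1 percentage points higher from compound 1 to compound 3 (within the scatter), adds a methyl two bonds along the chain from the amide-type nitrogen and changes nothing beyond the scatter.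

Compound 4 `CCCNC(=O)/C=C/c1ccccc1` has not yet been measured. It differs from compound 3 by hydrogen in place of methyl on a saturated chain carbon bound to an amide-type nitrogen and a saturated chain carbon; the same change, read one bond further out, is sec-butyl to propyl. Among the measured compounds shown here, this is the removal of a methyl on the chain, the same kind of change, in the opposite sense, as the one between compound 1 and compound 3, which stayed within the scatter. Compound 2, with its octyl chain, stands far below compound 3, but propyl is shorter than sec-butyl, not longer, so that comparison gives no reason to expect a drop. Compound 4 is therefore expected to show a step of a number 5 percentage points lower from compound 3 to compound 4 (within the scatter), within the scatter. The value estimated for compound 4 is 72%, with a range from 58% to 84%.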

Compound 4, percent growth inhibition at one concentration: 63%
For compound 4 the middle estimate is 9 percentage points above the measured one; measured number inside the range.
By their numbers in this assay, from the lowest: compound 2; then compound 4; then compounds 1 and 3 (each within the scatter of the next).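

In this assay hydrogen in place of methyl on a saturated chain carbon bound to an amide-type nitrogen and a saturated chain carbon, read as sec-butyl to propyl, gives a number 14 percentage points lower from compound 3 to compound 4 (beyond the scatter) and so shows that this methyl counts, whereas the methyl added further along the chain in the earlier step left the number within the scatter. Propyl in place of isopropyl on an amide-type nitrogen points the same way with a number 13 percentage points lower from compound 1 to compound 4 (beyond the scatter) so that in both pairs the straight propyl chain stands under the branched chain. Chain length also shows its first single-place step: hydrogen in place of pentyl on a saturated chain carbon, three bonds along the chain from an amide-type nitrogen, gives a number 21 percentage points higher from compound 2 to compound 4 (beyond the scatter) which places propyl above octyl, so the straight chains differ among themselves as well.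

Nothing among the data offers a measured reason for either difference. From the compounds shown here alone, it remains open how a butyl or hexyl chain on the amide-type nitrogen would read, and whether a tert-butyl or cyclopentyl group would hold the number seen with isopropyl and sec-butyl.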